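Benzylthio triazole series: halogen and its place on the benzyl ring

This account rests on a few compounds, and the source may have more. Where it says the series, first, only, none or still open, it means among the compounds named here.

compound 1 `Clc1cccc(CSc2nnc(-c3ccncc3)n2-c2ccccc2)c1`: 11200 nM
compound 2 `Brc1cccc(CSc2nnc(-c3ccncc3)n2-c2ccccc2)c1`: 7040 nM
compound 3 `Clc1ccc(CSc2nnc(-c3ccncc3)n2-c2ccccc2)cc1`: 16900 nM

All three were run in a functional assay on HepG2 cells (Homo sapiens) for inhibition, read by MTT assay, with a stated time of 48 h; a higher number here means a weaker inhibitor, a lower number a stronger inhibitor. They share one core and differ only in the halogen on the benzyl ring and in its place. The change from compound 1 to compound 2 is bromo in place of chloro on an aromatic carbon; it gave a 1.6-fold lower number from compound 1 to compound 2 (0.20 log units; within the scatter). Compound 1 and compound 3 differ by 4-chlorophenyl in place of 3-chlorophenyl on a saturated chain carbon bound to a sulfur, with a 1.5-fold higher number from compound 1 to compound 3 (0.18 log units; within the scatter). Among the measured compounds shown here, from compound 2 to compound 3 the step is a 2.4-fold higher number from compound 2 to compound 3 (0.38 log units; beyond the scatter), the only step among the three beyond the scatter.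

Compound 4 `Brc1ccc(CSc2nnc(-c3ccncc3)n2-c2ccccc2)cc1` has not been measured. It differs from compound 3 by bromo in place of chloro on an aromatic carbon. This is the same kind of change as that from compound 1 to compound 2, not the same: in compound 1 the halogen sits meta to a large group, in compound 3 para to a large group. In this assay a step of about a 1.5-fold lower number from compound 3 to compound 4 (0.19 log units; within the scatter) is expected from compound 3 to compound 4, resting on compound 1 to compound 2 having shown a 1.6-fold lower number from compound 1 to compound 2 (0.20 log units; within the scatter) for the same halogen exchange. Compound 4 is therefore estimated at 11000 nM, with a range from 5000 nM to 25000 nM.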

Compound 4, half-maximal inhibitory concentration: 12900 nM
The estimate for compound 4 lay 1.2-fold (0.07 log units) below the measured number, and the stated range covers the measured number.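

In this assay the bromo for chloro exchange on an aromatic carbon gives a 1.3-fold lower number from compound 3 to compound 4 (0.12 log units; within the scatter) and thus no separation of these two compounds, while the steps with a change of halogen place, a 1.8-fold higher number from compound 2 to compound 4 (0.26 log units; within the scatter) and a 1.2-fold higher number from compound 1 to compound 4 (0.06 log units; within the scatter) in turn, also stay inside the usual noise. The exchange reads alike whether the halogen sits as in compound 1 or para to a large group, and the two steps do not differ: the same change on two cores in this assay, a 1.6-fold lower number (0.20 log units; within the scatter) from compound 1 to compound 2 and a 1.3-fold lower number (0.12 log units; within the scatter) from compound 3 to compound 4, 1.2-fold (0.08 log units) apart, within the scatter of two such steps. That agreement rests on two pairs, each within the scatter, so it shows neither a real gain from bromo over chloro nor a rule that would hold on other cores.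

Still open, as far as these compounds go, is how the benzyl ring behaves with a group other than a single halogen, such as a methoxy group, a carboxylic acid or an amine. Also open, from the compounds shown here alone, is the effect of a longer chain on the sulfur in place of the benzyl group.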